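This account rests on a few compounds, and the source may have more. Where it says the series, first, only, none or still open, it means among the compounds named here.

Compound 1 `O=C1N(Cc2ccc(Br)cc2)c2ccc(F)cc2C1(O)Cc1nnn[nH]1`: > 100000 nM
Compound 2 `CCN1C(=O)C(O)(Cc2nnn[nH]2)c2cc(Br)ccc21`: > 100000 nM

Both entries come from a functional assay on BT-549 cells (Homo sapiens) for antiproliferative activity, read by MTT assay, with a stated time of 48 h (on this read-out lower numbers stand for stronger inhibition and higher numbers for weaker inhibition), and neither is an exact number. In this assay compound 2 gives > 100000 nM, which is a limit of the assay. Compound 1 gives > 100000 nM, which is also a limit. For the measured compounds named here, compound 2 therefore has no exact position on the scale, and the only other value available to compare it with is a limit too.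

Compound 3 `O=C1N(Cc2ccc(Br)cc2)c2ccc(Br)cc2C1(O)Cc1nnn[nH]1` has not yet been measured. The structural change from compound 2 is 4-bromophenyl in place of methyl on a saturated chain carbon bound to an amide-type nitrogen in a ring. Put in words, 4-bromophenyl stands in place of methyl on a saturated chain carbon bound to an amide-type nitrogen in a ring. Cut one bond further out, the same change reads ethyl to 4-bromobenzyl.

Going by the values given here, no step between measured compounds is available to show how large such a change might be. Compound 2 gives only a limit, and because of the limit of > 100000 nM in this assay, at which 2 of the 2 values shown sit, the expectation is no step beyond the scatter in this assay, in either direction. The expected change is a number no higher from compound 2 to compound 3 (the limit leaves the size open). Compound 3 is estimated at 100000 nM, with an expected range from 30000 nM to 150000 nM.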

Compound 3, half-maximal inhibitory concentration: 88800 nM
Compound 3: the middle estimate sits 1.1-fold (0.05 log units) above what was measured; low and high end bracket the measured number.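

In this assay, for the compounds shown here, compound 3 gives 88800 nM, the first exact number in this small set, so this end of the scale can now be read with a real value. Putting 4-bromophenyl in place of methyl on a saturated chain carbon bound to an amide-type nitrogen in a ring gives an at least 1.1-fold lower number from compound 2 to compound 3 (0.05 log units; that floor lies within the scatter), while bromo in place of fluoro on an aromatic carbon gives an at least 1.1-fold lower number from compound 1 to compound 3 (0.05 log units; that floor lies within the scatter). Neither floor goes beyond the scatter, and the true size of each step stays unknown because the other compound in each pair has only a limit: the limit of > 100000 nM in this assay, at which 2 of the 3 values shown sit.

The compounds shown therefore leave open whether either change has any real effect on the number in this assay. They also leave open whether a different group at the same place, such as a longer chain or a carboxylic acid in place of 4-bromobenzyl, would give a number clearly away from this end of the scale.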